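A few compounds are considered here, and "the series" means these few. Any claim that something is new, unique, unknown or untested is made for them only; others in the source may bear on it.

Compound 1 `CONC(=O)c1cccc(CSc2cnc(Nc3ccccn3)s2)c1` and compound 2 `CNC(=O)c1cccc(NCc2cnc(Nc3ccccn3)s2)c1` share a core and differ in the linker and in the amide. In a functional assay on L2987 cells (Homo sapiens) for antiproliferative activity (a lower number here means a stronger inhibitor, a higher number a weaker inhibitor), compound 1 gives only a limit of > 2500 nM and no number. In this assay compound 2 likewise gives only a limit of > 2500 nM. Both values sit at the limit of > 2500 nM in this assay, at which 2 of the 2 values shown sit, so compound 2 stands level with compound 1 on the numbers shown, and no measured step between them exists. Compound 3 `CNC(=O)c1ccc(F)c(NCc2cnc(Nc3ccccn3)s2)c1` differs from compound 2 by fluoro in place of hydrogen on an aromatic carbon. With compound 2 at a limit, no number anchors the step. The expected change is a step that the limit leaves unreadable from compound 2 to compound 3, that is, none beyond the scatter. Compound 3 is therefore estimated at 4000 nM, with a range from 1500 nM to 12000 nM, and it is expected most likely to return again only a limit.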

Compound 3, half-maximal inhibitory concentration: > 2500 nM
Compound 3: no number, only a limit; the forecaster's own chance of this, stated with the estimate: 70%; the middle value is on the limit's open side.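

Compound 2 and compound 3 both return only a limit in this assay, so no step can be read for fluoro in place of hydrogen: the limit of > 2500 nM in this assay, at which 3 of the 3 values shown sit.

The compounds shown leave open what, if anything, changes activity on this shared core, as none yields a number.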